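Azetidine nitrogen substituent swap on the spiro amide series

The compounds below may be only part of what the source reports. "The series", "measured", "known", "first", "only" and "open" are said of these compounds alone.

Measured so far:
- compound 1 `CS(=O)(=O)N1CC2(CC(NC(=O)c3cc(-c4ccccc4)no3)C2)C1`: 76%
- compound 2 `CN(C)C(=O)CCNC(=O)c1cc(-c2ccccc2F)no1`: > 100%

For the measured compounds named here, in an ADME assay on microsomes from liver (Homo sapiens) for metabolic stability, with a stated time of 0.5 h, tested at 0.5 mg/mL (a lower number here means that less of the compound is left, a higher number that more of the compound is left), compound 1 gives 76%, the only plain number in the set. Going by the values given here, compound 2 reaches the assay limit of > 100% in this assay, a limit and not a number; it is the one value sitting at the limit of > 100% in this assay, at which 1 of the 2 values shown sits. Among the compounds with values here, no pair of measured compounds differs in a single place, so no measured step is available.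

Compound 3 `CCN1CC2(CC(NC(=O)c3cc(-c4ccccc4)no3)C2)C1` is not yet measured. Its difference from compound 1 is ethyl in place of methylsulfonyl on an amine nitrogen in a ring, in words: ethyl in place of methylsulfonyl on an amine nitrogen in a ring. Without a comparable measured step, the expectation is a change of no more than the usual scatter in this assay, in either direction. Compound 3 is expected to give 68% in this assay, with a range from 40% to 95%. The step from compound 1 to compound 3 is thus estimated as a number 8 percentage points lower from compound 1 to compound 3 (within the scatter).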

Compound 3, percent of the compound remaining: 100%
For compound 3 the middle estimate is 32 percentage points below the measured one; the whole stated range lies below it.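

In this assay the amine nitrogen in a ring proves to be a position where the read-out responds to the substituent, with a number 24 percentage points higher from compound 1 to compound 3 (beyond the scatter). Methylsulfonyl is thus not required here for stability in this assay; the ethyl that enters has fewer heavy atoms and no hydrogen-bond acceptors, and the data cannot say which of these differences, if either, carries the step. Little of the scale remains for telling further gains at this position apart, as the read-out ends at a limit: the limit of > 100% in this assay, at which 1 of the 3 values shown sits.

Going by these compounds, whether the step comes from losing the sulfonyl group or from the ethyl itself stays open; an acetyl group, a propyl chain or a carboxylic acid on this nitrogen would help separate the two. On these data alone, whether the same swap holds on any other core also stays open.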